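Longer Chain and Dimethylated Sulfonamide on Compound 1's Core

The compounds below may be only part of what the source reports. "The series", "measured", "known", "first", "only" and "open" are said of these compounds alone.

Measured in an assay on isolated protein for inhibition of Indoleamine 2,3-dioxygenase 1 (Homo sapiens), read by fluorescence, with a stated time of 60 min; on this read-out lower numbers stand for stronger inhibition and higher numbers for weaker inhibition:
Compound 1, `NS(=O)(=O)CCNc1nonc1/C(=N/O)Nc1ccc(F)c(Br)c1`: 71 nM
Compound 2, `NNS(=O)(=O)CCNc1nonc1/C(=N/O)Nc1ccc(F)c(Br)c1`: 135 nM

Compound 1 gives the lowest of the two numbers; its nearest neighbour is compound 2, with a 1.9-fold higher number from compound 1 to compound 2 (0.28 log units; within the scatter). Compound 3, `CN(C)S(=O)(=O)CCCNc1nonc1/C(=N/O)Nc1ccc(F)c(Br)c1`, differs from compound 1 by (dimethylsulfamoyl)methyl in place of sulfamoyl on a saturated chain carbon, two bonds along the chain from a nitrogen on an aromatic ring. Among the compounds with values here, no measured step touches this change; the only step known, a 1.9-fold higher number from compound 1 to compound 2 (0.28 log units; within the scatter), alters the sulfonamide nitrogen and stays within the scatter, so nothing here points to a shift beyond the scatter in this assay. Compound 3 is therefore expected near 95 nM, ranging from 30 nM to 300 nM, an expected step of a 1.3-fold higher number from compound 1 to compound 3 (0.13 log units; within the scatter).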

Compound 3, half-maximal inhibitory concentration: 97 nM
Estimate against measurement, compound 3: 1.0-fold (0.01 log units) below, within the range that was stated.
By their numbers in this assay, from the lowest: compounds 1, 3 and 2 (each within the scatter of the next).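

Replacing sulfamoyl with (dimethylsulfamoyl)methyl lengthens the chain and removes the sulfonamide's hydrogen-bond donor, yet the result stays within the scatter of both neighbours (a 1.4-fold higher number from compound 1 to compound 3 (0.14 log units; within the scatter); a 1.4-fold lower number from compound 2 to compound 3 (0.14 log units; within the scatter)). At this saturated chain carbon, 2-sulfamoylethyl can therefore give way to 3-(dimethylsulfamoyl)propyl without a shift beyond the scatter. No available evidence explains this outcome.

Chain length and dimethylation changed together, so their separate contributions remain unknown. Also open, going by these compounds, is how a carboxylic acid or an amine at the chain end would compare.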